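Iodophenyl amide on the nitrophenylhydrazone carbonyl

The compounds below may be only part of what the source reports. "The series", "measured", "known", "first", "only" and "open" are said of these compounds alone.

Compound 1 `CC(/C=N/Nc1ccc([N+](=O)[O-])cc1)=N\NC(=O)c1ccccc1N` gives 4900 nM in a functional assay on cells (Splenocyte, Mus musculus, strain BALB/c) for inhibition, read by scintillation counting and thymidine incorporation, with a stated time of 72 h; on this read-out higher numbers stand for weaker inhibition and lower numbers for stronger inhibition. Compound 2 `CC(/C=N/Nc1ccc([N+](=O)[O-])cc1)=N\NC(=O)c1cccc(C)c1` reaches only the assay limit, > 12000 nM, in this assay. For the measured compounds named here, the single measured step, an at least 2.4-fold higher number from compound 1 to compound 2 (0.38 log units; beyond the scatter), rests on (the limit of > 12000 nM in this assay, at which 1 of the 2 values shown sits). Compound 3 `CC(/C=N/Nc1ccc([N+](=O)[O-])cc1)=N\NC(=O)c1ccccc1I` differs from compound 2 by 2-iodophenyl in place of 3-methylphenyl on a carbonyl carbon. Going by the values given here, no measured step covers this change; the step of an at least 2.4-fold higher number from compound 1 to compound 2 (0.38 log units; beyond the scatter) compares two other groups on the same carbonyl carbon and says nothing direct about a 2-iodophenyl, so no shift beyond the scatter is expected in this assay. The step is estimated as an at least 1.2-fold lower number from compound 2 to compound 3 (0.07 log units; that floor lies within the scatter). Compound 3 is expected at 10000 nM, range 3000 nM to 30000 nM, with a fair chance of another limit.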

Compound 3, half-maximal inhibitory concentration: 2980 nM
For compound 3 the middle estimate is 3.4-fold (0.53 log units) above the measured one; the measured number lies below the stated range.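

With a 2-iodophenyl on the carbonyl carbon, inhibition in this assay returns to a measurable value, an at least 4.0-fold lower number from compound 2 to compound 3 (0.60 log units; beyond the scatter). That size is only a floor, and compound 2 stands at a limit: the limit of > 12000 nM in this assay, at which 1 of the 3 values shown sits. Measurable inhibition is thus not confined to the 2-aminophenyl of compound 1, since the swap of amino for iodo gives a 1.6-fold lower number from compound 1 to compound 3 (0.22 log units; within the scatter), so the two groups cannot be told apart here.

Still open, on these data alone, is whether the iodo or its ring position matters, as 2-iodophenyl and 3-methylphenyl differ in both. A 2-methylphenyl or a 3-iodophenyl on the same carbonyl carbon would separate the two.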